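A larger side group on compound 1

This account rests on a few compounds, and the source may have more. Where it says the series, first, only, none or still open, it means among the compounds named here.

Compound 1 `Fc1ccc(Nc2cc3[nH]c(Nc4cc(N5CCNCC5)ccn4)nc3cn2)cc1C(F)(F)F`: 31000 nM
Compound 2 `C[C@@H]1CN(c2ccc(Nc3nc4cnc(Nc5ccc(F)c(C(F)(F)F)c5)cc4[nH]3)nc2)C[C@H](C)O1`: 8500 nM
Compound 3 `C[C@H]1CN(c2ccc(Nc3nc4cnc(Nc5cccc(C(F)(F)F)c5)cc4[nH]3)nc2)CCN1`: 25000 nM

These numbers come from an ADME assay on CHO cells (Cricetulus griseus) for cytotoxicity, read by MTT assay; a higher number here means that more compound is tolerated, a lower number that less compound is tolerated. Compound 1 and compound 3 lie within the scatter of each other, while compound 2 sits lower than compound 1, beyond the scatter.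

Compound 4 `O=C(c1ccnc(Nc2nc3cnc(Nc4ccc(F)c(C(F)(F)F)c4)cc3[nH]2)c1)N1CCN(C2CC2)CC1` is not yet measured. It carries (4-cyclopropylpiperazin-1-yl)carbonyl in place of piperazin-1-yl on an aromatic carbon. Among the compounds with values here, no measured pair isolates this change, so any forecast is loose. Within the data shown here, with compound 2 at 8500 nM as the only low reading, a moderate drop in this assay is expected. The estimated step runs a 2.2-fold lower number from compound 1 to compound 4 (0.35 log units; beyond the scatter). For compound 4 the expected value is 14000 nM, with an estimated range of 5000 nM to 35000 nM.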

Compound 4, half-maximal cytotoxic concentration: 30000 nM
The estimate for compound 4 lay 2.1-fold (0.33 log units) below the measured number; the range from low to high includes it.
By their numbers in this assay, from the lowest: compound 2; then compounds 3, 4 and 1 (each within the scatter of the next).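

In this assay, within the data shown here, the step is a 1.0-fold lower number from compound 1 to compound 4 (0.01 log units; within the scatter), the first reading of a single change at this position. On this aromatic carbon, opposite the ring nitrogen, the larger (4-cyclopropylpiperazin-1-yl)carbonyl therefore takes the place of piperazin-1-yl with no difference beyond the scatter, at least in this one pair. Nothing available gives a reason for this result. On these data alone, the carbonyl and the cyclopropyl enter together, so what each contributes alone remains open. As far as these compounds go, how a carboxylic acid or a longer chain on this carbon would read also remains open.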